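The compounds below may be only part of what the source reports. "The series", "measured", "known", "first", "only" and "open" are said of these compounds alone.

Of the compounds shown here, three sharing one core have been tested in a functional assay on the whole organism (strain Wistar albino) for inhibition, with Rattus norvegicus as the target, read by paw edema, with a stated time of 4 h, at a dose of 70 mg/kg by the oral route; a lower number here means less inhibition, a higher number more inhibition at the dose given (going by the name of the read-out). Compound 1 `CC(C)Cc1ccc(C(C)c2nnc3sc(COc4ccc(Cl)cc4Cl)nn23)cc1` gives 38.6%, compound 2 `CC(C)Cc1ccc(C(C)c2nnc3sc(-c4ccc(N)cc4)nn23)cc1` gives 78.8%, and compound 3 `CC(C)Cc1ccc(C(C)c2nnc3sc(Nc4ccccc4)nn23)cc1` gives 68.2%. Compound 2 stands highest of the three, as a number 10.6 percentage points lower from compound 2 to compound 3 (beyond the scatter) and a number 40.2 percentage points higher from compound 1 to compound 2 (beyond the scatter) show. Compound 4 `Cc1ccc(Nc2nn3c(C(C)c4ccc(CC(C)C)cc4)nnc3s2)c(C)c1` is not yet measured; it differs from compound 2 in one place: (2,4-dimethylphenyl)amino in place of 4-aminophenyl on an aromatic carbon. The step that bears on it most is a number 10.6 percentage points lower from compound 2 to compound 3 (beyond the scatter), where anilino likewise took the place of 4-aminophenyl; a number 29.6 percentage points higher from compound 1 to compound 3 (beyond the scatter) also shows the anilino compound well above compound 1. Going by the values given here, no measured step covers the two methyl groups of compound 4. A modest decrease is therefore expected, a number 12.8 percentage points lower from compound 2 to compound 4 (beyond the scatter). Compound 4 is estimated at 66%, with a range from 52% to 80%.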

Compound 4, a percentage reported as inhibition, in the whole organism at one dose (the size of the read-out at that dose, not a potency): 53%
Estimate against measurement, compound 4: 13 percentage points above; the range from low to high includes it.
By their numbers in this assay, from the lowest: compound 1; then compound 4; then compound 3; then compound 2.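

Going by these compounds alone, the two methyl groups of the 2,4-dimethylphenyl group lower the reading in this assay relative to the plain phenyl on the same nitrogen (a number 15.2 percentage points lower from compound 3 to compound 4 (beyond the scatter)), a change the earlier compounds did not cover. (2,4-Dimethylphenyl)amino therefore falls well short of 4-aminophenyl (a number 25.8 percentage points lower from compound 2 to compound 4 (beyond the scatter)), yet remains ahead of (2,4-dichlorophenoxy)methyl (a number 14.4 percentage points higher from compound 1 to compound 4 (beyond the scatter)). Nothing available explains these differences. Open, on these data alone, is whether both methyl groups are needed for the drop or a single one would produce it. Also open, as far as these compounds go, is how a methoxy group or an amine on that phenyl ring would read.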